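Trading One Five-Membered Ring for Another

A few compounds are considered here, and "the series" means these few. Any claim that something is new, unique, unknown or untested is made for them only; others in the source may bear on it.

Within the data shown here, compound 2 `CC(C)(C)c1cc(NC(=O)N2CCCN(c3ncc(C(F)(F)F)cc3Cl)CC2)no1` is the only one of the pair with an actual number in a physicochemical assay for solubility, at pH 7.4; on this read-out lower numbers stand for lower solubility and higher numbers for higher solubility: compound 2 gives 0.6 ug/mL. Compound 1 `O=C(Nc1ccc(Cl)c(Cl)c1)N1CCCN(c2ncc(C(F)(F)F)cc2Cl)CC1` instead stops at a limit of this assay, < 0.1 ug/mL. Compound 1 therefore stands at the limit of < 0.1 ug/mL in this assay, at which 1 of the 2 values shown sits. Among the measured compounds shown here, the one measured step runs an at least 6.0-fold higher number from compound 1 to compound 2 (0.77 log units; beyond the scatter). Compound 3 `Cn1nc(C(C)(C)C)cc1NC(=O)N1CCCN(c2ncc(C(F)(F)F)cc2Cl)CC1` brings a smaller change: 1-methyl-3-(tert-butyl)-1H-pyrazol-5-yl in place of 5-(tert-butyl)-1,2-oxazol-3-yl on an amide-type nitrogen. For the measured compounds named here, no measured step covers this exact exchange, so only a modest shift, a 1.7-fold higher number from compound 2 to compound 3 (0.22 log units; within the scatter), is expected, possibly within the scatter. Compound 3 is estimated at 1 ug/mL, in a range from 0.3 ug/mL to 4 ug/mL.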

Compound 3, solubility: 10 ug/mL
Estimate against measurement, compound 3: 10-fold (1.00 log units) below, outside the stated range (above it).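

In this assay, the exchange at this amide-type nitrogen proves far from minor: it gives a 17-fold higher number from compound 2 to compound 3 (1.22 log units; beyond the scatter). Both groups are five-membered aromatic rings with 2 hetero atoms and have matching hydrogen-bond donor and acceptor counts, so those counts alone do not predict the outcome here. Measured against the 3,4-dichlorophenyl group, the new ring gives an at least 100-fold higher number from compound 1 to compound 3 (2.00 log units; beyond the scatter), and compound 1 rests on a limit rather than a number: the limit of < 0.1 ug/mL in this assay, at which 1 of the 3 values shown sits.

The compounds shown cannot separate the effect of the ring atoms from that of the 1-methyl group. On these data alone, whether an amine or a carboxylic acid on this ring would shift the number further remains open.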